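Adding Chloro to a Compound Inactive in Cytotoxicity

The compounds below may be only part of what the source reports. "The series", "measured", "known", "first", "only" and "open" are said of these compounds alone.

compound 1 `CCOC(=O)C1(C(=O)Nc2ccccc2)CC1c1cc(OC)c(OC)c(OC)c1`: > 100000 nM; > 100000 nM (2 entries)
compound 2 `CCOC(=O)[C@]1(C(=O)Nc2ccccc2)C[C@@H]1c1cc(OC)c(OC)c(OC)c1`: > 100000 nM

Compound 1 `CCOC(=O)C1(C(=O)Nc2ccccc2)CC1c1cc(OC)c(OC)c(OC)c1` and compound 2 `CCOC(=O)[C@]1(C(=O)Nc2ccccc2)C[C@@H]1c1cc(OC)c(OC)c(OC)c1` share the same core; they differ only in that one is drawn with a defined configuration and the other without (the fact that one of compounds 1 and 2 is drawn with a defined configuration and the other without, at the place where they differ). In a functional assay on HeLa cells (Homo sapiens) for cytotoxicity, read by MTT assay, with a stated time of 48 h (a lower number here means a stronger inhibitor, a higher number a weaker inhibitor), compound 1 gives > 100000 nM; > 100000 nM (2 entries), which is a limit of the assay rather than a number. In this assay compound 2 gives > 100000 nM, again only a limit. Compound 2 thus stands at the limit of this assay, with no single number to place it. Compound 3 `CCOC(=O)[C@]1(C(=O)Nc2ccccc2Cl)C[C@@H]1c1cc(OC)c(OC)c(OC)c1` differs from compound 2 by chloro in place of hydrogen on an aromatic carbon. Within the data shown here, no step between measured compounds is available, and the measured values sit at the limit (the limit of > 100000 nM in this assay, at which 1 of the 2 values shown sits), so in this assay no step beyond the scatter is expected; the expected step is a number no higher from compound 2 to compound 3 (the limit leaves the size open). For compound 3 a value of 100000 nM is estimated, with a range from 30000 nM to 300000 nM.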

Compound 3, half-maximal inhibitory concentration: > 100000 nM
Compound 3 ended at the assay's limit; the forecaster's own chance of this, stated with the estimate: 80%; the middle value sits exactly at the limit.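

Compound 2 and compound 3 both stand at a limit of this assay rather than at a number, so no step can be read between them: the limit of > 100000 nM in this assay, at which 2 of the 3 values shown sit.

The compounds shown leave open whether chloro in place of hydrogen on an aromatic carbon changes cytotoxicity at all.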